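A few compounds are considered here, and "the series" means these few. Any claim that something is new, unique, unknown or untested is made for them only; others in the source may bear on it.

In an assay on CHO cells for displacement of a labelled ligand from adenosine receptor A2b (Homo sapiens), read by scintillation counting, with a stated time of 75 min (a higher number here means a weaker inhibitor, a lower number a stronger inhibitor), compound 1 `COc1cccc(/C=C/C(=O)Nc2nc3ccccc3c(=O)s2)c1` gives 679 nM. Compound 2 `COc1cccc(/C=C/CC(=O)Nc2nc3ccccc3c(=O)s2)c1` carries the same side phenyl ring but differs from compound 1 in its core; the difference between the two cores is not broken down here. In this assay compound 2 reaches only >= 1000 nM, which is a limit of the assay and not a number (the limit of >= 1000 nM in this assay, at which 1 of the 3 values shown sits). Compound 3 `O=C(C/C=C/c1cccc(Cl)c1)Nc1nc2ccccc2c(=O)s1` arises from compound 2 by chloro in place of methoxy on an aromatic carbon. In this assay compound 3 also stops at a limit of the assay, > 1000 nM (the limit of > 1000 nM in this assay, at which 1 of the 3 values shown sits). The step that the two limits leave unreadable from compound 2 to compound 3 therefore cannot be read, since both of its ends are limits. Compound 4 `O=C(/C=C/c1cccc(Cl)c1)Nc1nc2ccccc2c(=O)s1` is the corresponding partner of compound 1: the change from compound 1 to compound 4 is chloro in place of methoxy on an aromatic carbon, the same change as that between compound 2 and compound 3, made at the same place. Among the measured compounds shown here, compound 1 stands alone as the only number in this assay; the two other values are limits. What this change does to affinity is thus not readable from compound 2 and compound 3, and the expectation for compound 4 rests only on compound 1, whose value 679 nM is the single anchor available. For compound 4 the expected step is a 1.2-fold higher number from compound 1 to compound 4 (0.07 log units; within the scatter). Compound 4 is accordingly estimated at 800 nM in this assay, with a range expected from 250 nM to 2500 nM.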

Compound 4, inhibition constant: > 1000 nM
Compound 4 was reported as a limit; the forecaster's own chance of this, stated with the estimate: 35%; middle value at least 1.2-fold (0.09 log units) from the limit.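

Going from 3-methoxyphenyl to 3-chlorophenyl on the core of compound 1 gives, in this assay, an at least 1.4-fold higher number from compound 1 to compound 4 (0.16 log units; that floor lies within the scatter), so all that can be read is a floor and not the true size of the step. Compound 4 stops at > 1000 nM, which is a limit of the assay and not a number, and it shares that limit with another compound: the limit of > 1000 nM in this assay, at which 2 of the 4 values shown sit.

The same change on the core of compound 2 cannot be read, with both of its ends being limits, so neither the size nor the direction of the change can be compared across the two cores, and the starting point on that core is itself a limit: the limit of >= 1000 nM in this assay, at which 1 of the 4 values shown sits.

On these data alone, it remains open whether the change from methoxy to chloro has any real effect on the core of compound 1, and whether an amine or a carboxylic acid at the same place would give a number on either core. Also open, as far as these compounds go, is what a longer chain in place of the methoxy would do, and whether any compound on the core of compound 2 gives a number at all in this assay.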